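Trimming a Benzyl Group on a Spirocyclic Core

This account rests on a few compounds, and the source may have more. Where it says the series, first, only, none or still open, it means among the compounds named here.

Measured compounds:
compound 1 `CC(C)C[C@]1(O)NC(=O)[C@]2(OC(Cc3ccccc3)=CC2=O)[C@H]1O`: > 100000 nM
compound 2 `Cc1cc2c(c(=O)[nH]1)OC(C(=O)CC(C)C)O2`: > 100000 nM
compound 3 `CC1=CC(=O)[C@@]2(O[C@H]2C(=O)CC(C)C)C(=O)N1`: "not determined" (no result reported)

The measurement is a functional assay on HeLa cells (Homo sapiens) for cytotoxicity, read by WST assay, with a stated time of 48 h; a higher number here means a weaker inhibitor, a lower number a stronger inhibitor. In this assay compound 1 reaches only a limit, > 100000 nM. Compound 2 likewise reaches only a limit, > 100000 nM. For compound 3 the entry is "not determined" (no result reported). Compound 1 therefore stands at the limit of > 100000 nM in this assay, at which 2 of the 3 values shown sit, and the numbers shown give no basis to place it above or below any other compound.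

Going by the values given here, no two measured compounds differ in a single place, so no measured step is available to guide an expectation. Compound 4 `CC1=CC(=O)[C@]2(O1)C(=O)N[C@@](O)(CC(C)C)[C@@H]2O` differs from compound 1 by hydrogen in place of phenyl on a saturated chain carbon bound to a double-bonded ring carbon. Because compound 1 already sits at the limit of > 100000 nM in this assay, at which 2 of the 3 values shown sit, the account expects the step that the limit leaves unreadable from compound 1 to compound 4 to amount to nothing beyond the scatter. The estimate for compound 4 is 150000 nM, with a range from 50000 nM to 500000 nM, and the result for compound 4 is expected most likely to come back as a limit rather than a number.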

Compound 4, half-maximal inhibitory concentration: > 100000 nM
Compound 4: a limit, no number; the forecaster's own chance of this, stated with the estimate: 85%; the middle value lies beyond the limit too.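

Compound 4, like compound 1, returns only a limit of the assay, so no step can be read between compound 1 and compound 4. The compounds shown leave open whether exchanging benzyl for methyl on the shared core changes cytotoxicity at all.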